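Ester in place of methylamide on the acrylamide series

The compounds below may be only part of what the source reports. "The series", "measured", "known", "first", "only" and "open" are said of these compounds alone.

Measured so far in an assay on a protein complex for inhibition of CDK8/Cyclin C (Homo sapiens), with a stated time of 1 h, tested at 10 uM; on this read-out lower numbers stand for less inhibition and higher numbers for more inhibition at the one concentration tested (going by the name of the read-out):
compound 1 `CNC(=O)/C=C/c1ccncc1-c1ccc2ccccc2c1` gives 101%
compound 2 `O=C(/C=C/c1ccncc1-c1ccc2[nH]ccc2c1)N1CCOCC1` gives 97%
compound 3 `CCOC(=O)/C=C/c1ccncc1-c1ccc2[nH]ccc2c1` gives 100%

Compound 1 stands highest of the three numbers in this assay, but its nearest neighbour compound 3 sits within the scatter of it, and compound 2 does as well, so no order among the three can be read. All three numbers are level with one another at the tested concentration.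

Compound 4 `CCOC(=O)/C=C/c1ccncc1-c1ccc2ccccc2c1` is the next compound in line and is yet to be measured. It differs from compound 1 in one place: ethoxy in place of methylamino on a carbonyl carbon.

Within the data shown here, one measured step bears on this change. Between compound 2 and compound 3 the carbonyl substituent is exchanged on the same side of the molecule, and that step gave a number 3 percentage points higher from compound 2 to compound 3 (within the scatter). A carbonyl-side exchange therefore left the read-out essentially unchanged in the one case where it was measured, and compound 1 already sits at the top of the scale.

Compound 4 is therefore expected to show no step beyond the scatter, estimated as a number 1 percentage points lower from compound 1 to compound 4 (within the scatter). The estimate for compound 4 in this assay is 100%, with a range from 92% to 105%.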

Compound 4, a percentage reported as inhibition, at one concentration (the size of the read-out at that concentration, not a potency): 102%
Compound 4: the middle estimate sits 2 percentage points below what was measured; the measured number falls inside the stated range.
By their numbers in this assay, from the lowest: compounds 2, 3, 1 and 4 (each within the scatter of the next).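

In this assay, the exchange of methylamino for ethoxy on the carbonyl carbon gives a number 1 percentage points higher from compound 1 to compound 4 (within the scatter). This is a second carbonyl-side exchange with no step beyond the scatter, this time on the core of compound 1 and with methylamino rather than morpholin-4-yl leaving, so at this position the amide hydrogen of compound 1 can be lost with no visible change in this read-out at the one concentration tested. Nothing measured here accounts for this flat outcome.

All four numbers lie level at the top of the scale, so this assay gives the size of the read-out at a single concentration and cannot say whether the ester and the amide differ in potency at lower concentrations. Also open, as far as these compounds go, is whether any carbonyl substituent at this position would bring the number down, for example a carboxylic acid, a primary amide or a longer chain on the ester oxygen in place of ethoxy.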